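A Carbonyl Enters the Hydrazide Arm of Compound 1

The source may report more compounds than this note shows. Statements on the series, on what has been measured and on what is new or still open speak of the compounds shown alone.

compound 1 `Cc1ccccc1NNC(=O)c1ccccc1NS(=O)(=O)c1cnc(O)nc1O` — > 20000 nM
compound 2 `Cc1ccccc1C(=O)NNC(=O)c1ccc(NS(=O)(=O)c2cnc(O)nc2O)cc1` — 7040 nM
compound 3 `O=C(NNC(=O)c1ccccc1Cl)c1cccc(NS(=O)(=O)c2cnc(O)nc2O)c1` — 2360 nM

Of the compounds shown here, three have been tested in a functional assay on MDA-MB-231 cells (Homo sapiens) for antiproliferative activity, read by MTT assay, with a stated time of 24 h; a lower number here means a stronger inhibitor, a higher number a weaker inhibitor. For compound 1 the assay reports no number at all but only a limit, > 20000 nM. This is the limit of > 20000 nM in this assay, at which 1 of the 3 values shown sits, so compound 1 stands at the weak end of what this assay can tell apart. In this assay compound 2 gives 7040 nM, and compound 3 gives 2360 nM; of these two numbers, compound 3 holds the lower one.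

Going by these compounds, compound 4 `O=C(NNC(=O)c1ccccc1NS(=O)(=O)c1cnc(O)nc1O)c1ccccc1F` is untested. It is built from compound 1 by one change: (2-fluorophenyl)carbonyl in place of 2-methylphenyl on an amine nitrogen. Compound 2 and compound 3 both carry a carbonyl on the corresponding nitrogen, as compound 4 would, and both give a number where compound 1 gives only a limit. Among the measured compounds shown here, no measured pair traces exactly this step, so the expectation rests on that comparison alone. A gain beyond the usual scatter is expected, an at least 2.5-fold lower number from compound 1 to compound 4 (0.39 log units; beyond the scatter), although the arrangement around the shared core of compound 1 is kept in compound 4 and differs from that of compound 2 and compound 3. Compound 4 is therefore estimated at 8000 nM, with a range from 2000 nM to 30000 nM.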

Compound 4, half-maximal inhibitory concentration: > 20000 nM
Compound 4: only a limit was reported (the forecaster's own chance of this, stated with the estimate: 30%); middle value at least 2.5-fold (0.39 log units) from the limit.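

In this assay compound 4 gives only a limit, > 20000 nM, and not a number. Compound 1 also gives only a limit, so no step between compound 1 and compound 4 can be read: the limit of > 20000 nM in this assay, at which 2 of the 4 values shown sit.

The compounds shown leave open whether (2-fluorophenyl)carbonyl in place of 2-methylphenyl on this nitrogen changes the activity at all.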